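From pentyloxy to benzyloxy in a whole-rat inhibition assay

The source may report more compounds than this note shows. Statements on the series, on what has been measured and on what is new or still open speak of the compounds shown alone.

- Compound 1 `O=C(O)c1cnc(-c2ccccc2)[nH]c1=O`: 50 mg/kg
- Compound 2 `CC(C)COc1ccccc1-c1ncc(C(=O)O)c(=O)[nH]1`: 0.5 mg/kg
- Compound 3 `CCCCCOc1ccccc1-c1ncc(C(=O)O)c(=O)[nH]1`: 3 mg/kg

All three values come from a functional assay on the whole organism (strain Sprague-Dawley) for inhibition, with Rattus norvegicus as the target, with a stated time of 10 min; a higher number here means that more compound is needed for the effect, a lower number that less compound is needed. Compound 3 holds the second highest of the three numbers, with a 6.0-fold higher number from compound 2 to compound 3 (0.78 log units; beyond the scatter) as its nearest gap and a 17-fold lower number from compound 1 to compound 3 (1.22 log units; beyond the scatter) as its furthest.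

The next compound is compound 4 `O=C(O)c1cnc(-c2ccccc2OCc2ccccc2)[nH]c1=O`. It differs from compound 3 as follows: phenyl in place of butyl on a saturated chain carbon bound to an oxygen on an aromatic ring. This is phenyl in place of butyl on a saturated chain carbon bound to an oxygen on an aromatic ring, or pentyloxy to benzyloxy.

Among the compounds with values here, no measured compound carries a ring in that chain, so the measured steps bear on this change only indirectly. The large steps, a 100-fold lower number from compound 1 to compound 2 (2.00 log units; beyond the scatter) and a 17-fold lower number from compound 1 to compound 3 (1.22 log units; beyond the scatter), both replace hydrogen on an aromatic carbon. Compound 4 keeps a chain on that oxygen, so it is expected to stay well under compound 1 at 50 mg/kg. The closer guide is the modest 6.0-fold higher number from compound 2 to compound 3 (0.78 log units; beyond the scatter), which alters the chain alone. A step of about that size at most is therefore expected in this assay, most likely within the scatter and with no firm direction. The estimated step is a 1.5-fold lower number from compound 3 to compound 4 (0.18 log units; within the scatter). For compound 4 the expected value is 2 mg/kg, with an estimated range from 0.5 mg/kg to 8 mg/kg.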

Compound 4, dose for 50% inhibition: 5 mg/kg
Estimate against measurement, compound 4: 2.5-fold (0.40 log units) below; measured number inside the range.
By their numbers in this assay, from the lowest: compound 2; then compounds 3 and 4 (each within the scatter of the next); then compound 1.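

In this assay, the step of a 1.7-fold higher number from compound 3 to compound 4 (0.22 log units; within the scatter) shows that a phenyl can take the place of butyl on the saturated chain carbon bound to the oxygen without a change that stands clear of the scatter, so pentyloxy and benzyloxy cannot be told apart at this position. The benzyloxy group still keeps a clear distance from the unsubstituted parent, with a 10-fold lower number from compound 1 to compound 4 (1.00 log units; beyond the scatter) for benzyloxy in place of hydrogen, so the advantage over hydrogen seen with the two open chains also holds for a chain that ends in a ring. Isobutoxy remains apart from benzyloxy, with a 10-fold higher number from compound 2 to compound 4 (1.00 log units; beyond the scatter) for phenyl in place of isopropyl, and thus the branched chain alone reaches the lowest number of the set, while nothing measured alongside these compounds accounts for any of these steps.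

On these data alone, whether that lowest number depends on the branching or on the length of the chain stays open, and a straight butoxy or a propoxy chain would bear on it. As far as these compounds go, it also stays open whether the benzyloxy ring tolerates further groups, such as a methoxy or a chlorine on it, and whether a cyclohexylmethoxy group behaves like benzyloxy or like isobutoxy.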